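Changing the group on the ring nitrogen of the shared core

This account rests on a few compounds, and the source may have more. Where it says the series, first, only, none or still open, it means among the compounds named here.

Compound 1 `Cc1ccccc1-c1nn(-c2cccc(Cl)c2)cc1CNCCN1CCN(C)CC1`: 16000 nM in an ADME assay on Huh-7 cells (Homo sapiens) for cytotoxicity; a higher number here means that more compound is tolerated, a lower number that less compound is tolerated
Compound 2 `Cc1ccccc1-c1nn(-c2ccc(F)cc2F)cc1CNCCCCO`: > 20000 nM, a limit of this assay
Compound 3 `Cc1ccccc1-c1nn(-c2ccc(F)cc2F)cc1CNC1CCN(S(C)(=O)=O)CC1`: > 20000 nM, a limit of this assay

Among the measured compounds shown here, compound 1 gives the only number in this assay. Compound 2 and compound 3 both sit at the limit of > 20000 nM in this assay, at which 2 of the 3 values shown sit. For the measured compounds named here, the single step between measured compounds, a step that the two limits leave unreadable from compound 2 to compound 3, alters a different place and its size cannot be read.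

Compound 4 `Cc1ccccc1-c1nn(Cc2ccc(F)cc2)cc1CNCCN1CCN(C)CC1` differs from compound 1 in one place: 4-fluorobenzyl in place of 3-chlorophenyl on an aromatic nitrogen. No measured step touches this place, so nothing shown speaks for a change in either direction, and a step within the scatter is expected. Compound 4 is therefore expected to give about 17000 nM, between 8000 nM and 36000 nM, which means an expected step of a 1.1-fold higher number from compound 1 to compound 4 (0.03 log units; within the scatter).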

Compound 4, half-maximal cytotoxic concentration: > 20000 nM
Compound 4: only a limit was reported (the forecaster's own chance of this, stated with the estimate: 40%); at least 1.1-fold (0.07 log units) between middle value and limit.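

On the aromatic nitrogen, 4-fluorobenzyl in place of 3-chlorophenyl gives an at least 1.2-fold higher number from compound 1 to compound 4 (0.09 log units; that floor lies within the scatter), so this place now has a step of its own in this assay. Compound 4 gives > 20000 nM, which is a limit of the assay. The true size of the step stays unknown because the values run into that ceiling: the limit of > 20000 nM in this assay, at which 3 of the 4 values shown sit.

The compounds shown leave open whether a 2-phenylethyl group or an unsubstituted benzyl on this nitrogen would also reach the limit. They also leave open whether a carboxylic acid on that ring would lower the number.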